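The source may hold more compounds than are shown below. What is called first, only, known or untested is meant among the compounds shown, and "the series" means these compounds.

Measured compounds:
Compound 1 `Cc1nc(-c2ccc(C(F)(F)F)cc2)sc1CNc1ccc(CC(=O)O)cc1`. In a functional assay on CHO cells for agonist activity at Free fatty acid receptor 1 (Homo sapiens) (on this read-out higher numbers stand for an effect only at larger amounts of compound and lower numbers for an effect already at smaller amounts), compound 1 gives < 10000 nM, which is a limit of the assay and not a number.
Compound 2 `Cc1nc(-c2ccc(C(F)(F)F)cc2)sc1CNc1ccc(CCCC(=O)O)cc1`. In this assay compound 2 gives < 10000 nM, likewise only a limit.
Compound 3 `O=C(O)CSc1ccc(NCc2cccc(Oc3ccccc3)c2)cc1`. In this assay compound 3 gives 324 nM.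

Within the data shown here, compound 2 thus stands at the limit of < 10000 nM in this assay, at which 2 of the 3 values shown sit, and the only true number in the set comes from compound 3, which carries a different core. The step that the two limits leave unreadable from compound 1 to compound 2 has both ends at the limit and cannot be sized.

Compound 4 `Cc1nc(-c2ccc(C(F)(F)F)cc2)sc1CNc1ccc(CC(C)C(=O)O)cc1` has not been measured. It differs from compound 2 as 1-carboxyethyl in place of 2-carboxyethyl on a saturated chain carbon bound to an aromatic carbon. Among the measured compounds shown here, the single measured step on this core, from compound 1 to compound 2, also alters the acid-bearing chain and is unreadable, so it gives no size for the present change; no other measured step bears on it. The expectation for compound 4 therefore rests mainly on the limit of compound 2 and on the number from compound 3, and is estimated at 1500 nM, with a range from 200 nM to 8000 nM. The estimate implies an expected step that the limit leaves unreadable from compound 2 to compound 4, a direction that cannot be checked against a limit.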

Compound 4, half-maximal effective concentration: 355 nM
The estimate for compound 4 lay 4.2-fold (0.63 log units) above the measured number; measured number inside the range.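

Compound 1 and compound 2 are each only a limit of the assay, so neither step to compound 4 can be read: the limit of < 10000 nM in this assay, at which 2 of the 4 values shown sit.

Left open is the size of the change in this assay on going from the 2-carboxyethyl chain of compound 2 to the 1-carboxyethyl chain of compound 4.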